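Compound 4 and the unreadable limits of its neighbours

This account rests on a few compounds, and the source may have more. Where it says the series, first, only, none or still open, it means among the compounds named here.

Compound 1 `COc1cc(O)ccc1N1CCN(CC(O)COc2cccc3ccccc23)CC1`: > 50000 nM, a limit
Compound 2 `COc1cc(O)ccc1N1CCN(CC(O)COc2ccc(O)c3ccccc23)CC1`: > 50000 nM, a limit
Compound 3 `Oc1ccccc1N1CCN(CC(O)COc2ccc(O)c3ccccc23)CC1`: > 50000 nM, a limit

In an ADME assay on HEK293 cells (Homo sapiens) for cytotoxicity, read by MTT assay, with a stated time of 48 h (a lower number here means a stronger inhibitor, a higher number a weaker inhibitor), compound 1 gives > 50000 nM, which is a limit and not a number. It has no numerical standing among its neighbours, for the set shows (the limit of > 50000 nM in this assay, at which 3 of the 3 values shown sit).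

Compound 4 `Oc1ccccc1N1CCN(CC(O)COc2cccc3ccccc23)CC1` has not yet been measured. It keeps the core of compound 1 and exchanges one group: 2-hydroxyphenyl in place of 4-hydroxy-2-methoxyphenyl on an amine nitrogen in a ring.

For the measured compounds named here, two measured steps bear on this change. Going by the values given here, the first is a step that the two limits leave unreadable from compound 1 to compound 2, with hydroxy in place of hydrogen on an aromatic carbon. The second is a step that the two limits leave unreadable from compound 2 to compound 3, and it makes the same exchange of groups that leads to compound 4. Neither step has a size that can be carried over.

Compound 3, which already carries 2-hydroxyphenyl, gives > 50000 nM, likewise a limit. On that basis, no step beyond the scatter is expected in this assay, in either direction. The estimated step is a step that the limit leaves unreadable from compound 1 to compound 4.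

For compound 4 the estimate is 60000 nM, with an expected range of 35000 nM to 150000 nM, and the assay is expected to report only a limit.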

Compound 4, half-maximal inhibitory concentration: > 50000 nM
Compound 4: only a limit was reported (the forecaster's own chance of this, stated with the estimate: 90%); the middle value lies beyond the limit too.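

Compound 4 adds no readable step: its comparisons with compound 1 and compound 3 in this assay join limits only, and all four compounds sit together: the limit of > 50000 nM in this assay, at which 4 of the 4 values shown sit.

The compounds shown leave open how far each lies beyond that limit, and so whether the exchanged groups make any difference in this assay at all.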